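This account rests on a few compounds, and the source may have more. Where it says the series, first, only, none or still open, it means among the compounds named here.

Measured in an ADME assay on Huh-7 cells (Homo sapiens) for cytotoxicity, with a stated time of 72 h; a higher number here means that more compound is tolerated, a lower number that less compound is tolerated:
Compound 1 `COC(=O)n1c(=O)c(C)cn([C@@H]2O[C@H](CO[Si](C)(C)C(C)(C)C)[C@@]3(OS(=O)(=O)C=C3N)[C@H]2O[Si](C)(C)C(C)(C)C)c1=O`: > 100000 nM, a limit.
Compound 2 `Cc1cn([C@@H]2O[C@H](CO[Si](C)(C)C(C)(C)C)[C@@]3(OS(=O)(=O)C=C3N)[C@H]2O[Si](C)(C)C(C)(C)C)c(=O)n(C(=O)CCCC(N)=O)c1=O`: > 100000 nM, a limit.

Compound 2 gives no number in this assay and stands at the limit of > 100000 nM in this assay, at which 2 of the 2 values shown sit. Compound 3 `CNC(=O)CCCC(=O)n1c(=O)c(C)cn([C@@H]2O[C@H](CO[Si](C)(C)C(C)(C)C)[C@@]3(OS(=O)(=O)C=C3N)[C@H]2O[Si](C)(C)C(C)(C)C)c1=O` carries methyl in place of hydrogen on an amide-type nitrogen, the terminal carbamoyl becoming methylcarbamoyl: methyl in place of hydrogen on an amide-type nitrogen. Going by the values given here, the one measured step bearing on this is a step that the two limits leave unreadable from compound 1 to compound 2, which put 3-carbamoylpropyl in place of methoxy on a carbonyl carbon. No size can be taken from it, so it offers only weak guidance. The expectation rests on compound 2, whose > 100000 nM is a limit. No change beyond the scatter is expected, in either direction, and compound 3 will probably also reach the limit. The expected step is a number no higher from compound 2 to compound 3 (the limit leaves the size open). For compound 3 the estimated value is 100000 nM, with an expected range of 50000 nM to 200000 nM.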

Compound 3, half-maximal cytotoxic concentration: > 100000 nM
Compound 3: only a limit was reported; the forecaster's own chance of this, stated with the estimate: 85%; the middle value lies on the limit itself.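

In this assay compound 3 gives > 100000 nM, which is a limit. No step among compound 1, compound 2 and compound 3 can therefore be read: the limit of > 100000 nM in this assay, at which 3 of the 3 values shown sit.

The compounds shown leave open whether methyl in place of hydrogen on the amide-type nitrogen changes the tolerated concentration at all.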